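Chlorine-for-fluorine swap in a series that gave no number

The source may hold more compounds than are shown below. What is called first, only, known or untested is meant among the compounds shown, and "the series" means these compounds.

Of the compounds shown here, three have so far been tested in a functional assay on U-937 cells (Homo sapiens) for cytotoxicity, read by MTT assay, with a stated time of 48 h (on this read-out higher numbers stand for weaker inhibition and lower numbers for stronger inhibition), and none of them yielded a numerical value. Compound 1 `Fc1cccc(-c2nc(Nc3ccccc3)c3ccccc3n2)c1` reached only the limit of the assay, > 50000 nM. Compound 2 `Fc1ccc2nc(-c3ccccc3)nc(Nc3ccccc3)c2c1` likewise stopped at the limit, > 50000 nM. Compound 3 `Fc1ccc(Nc2nc(-c3cccc(F)c3)nc3ccc(F)cc23)cc1` also returned nothing more than a limit, > 50000 nM. All three rest at the limit of > 50000 nM in this assay, at which 3 of the 3 values shown sit, so compound 3 stands level with the other two and nothing in the numbers separates it from them.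

Compound 4 `Fc1cccc(-c2nc(Nc3cccc(Cl)c3)c3cc(F)ccc3n2)c1` differs from compound 3 in a single place: 3-chlorophenyl in place of 4-fluorophenyl on a nitrogen on an aromatic ring. Among the compounds with values here, no step between two measured compounds is available to show what a change of this kind does in this assay. With every measured value resting at the limit, the expected step is a step that the limit leaves unreadable from compound 3 to compound 4, none beyond the scatter. Compound 4 is therefore expected to give 60000 nM, with a range from 20000 nM to 200000 nM. The most likely outcome is that the assay once more reports only a limit for compound 4 rather than a measured number.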

Compound 4, half-maximal inhibitory concentration: > 50000 nM
Compound 4: only a limit was reported; the forecaster's own chance of this, stated with the estimate: 80%; the middle value lies beyond the limit too.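

Within the data shown here, compound 3 and compound 4 both stop at a limit of the assay, so no step between them can be read in this assay. The compounds shown leave open what 3-chlorophenyl in place of 4-fluorophenyl does, and whether any compound on this shared core gives a measured number at all.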